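Side-chain swap from compound 1 to compound 4

The source may hold more compounds than are shown below. What is called first, only, known or untested is meant among the compounds shown, and "the series" means these compounds.

Measured so far in a functional assay on HCT-116 cells (Homo sapiens) for antiproliferative activity, read by sulforhodamine B assay, with a stated time of 72 h; a lower number here means a stronger inhibitor, a higher number a weaker inhibitor:
compound 1 `Cn1ncc(Cl)c1-c1cc(C(=O)N[C@@H]2CN[C@H](CCNS(C)(=O)=O)C[C@H]2c2ccc(F)c(F)c2)oc1Cl` gives 920 nM
compound 2 `Cn1ncc(Cl)c1-c1cc(C(=O)N[C@@H]2CN[C@H](CCCO)C[C@H]2c2ccc(Cl)c(Cl)c2)oc1Cl` gives 510 nM
compound 3 `C=CC[C@@H]1C[C@@H](c2ccc(Cl)c(Cl)c2)[C@H](NC(=O)c2cc(-c3c(Cl)cnn3C)c(Cl)o2)CN1` gives 780 nM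

In this assay compound 1 stands at 920 nM. Its value and those of compound 2 and compound 3 lie within the usual scatter of one another, so these three cannot be ranked.

The next compound is compound 4 `CNC(=O)C[C@@H]1C[C@@H](c2ccc(F)c(F)c2)[C@H](NC(=O)c2cc(-c3c(Cl)cnn3C)c(Cl)o2)CN1`, which keeps the rest of compound 1 and alters one side chain: methylcarbamoyl in place of (methanesulfonamido)methyl on a saturated chain carbon bound to a saturated ring carbon. In words, this puts methylcarbamoyl in place of (methanesulfonamido)methyl on a saturated chain carbon bound to a saturated ring carbon.

For the measured compounds named here, only one measured step bears on this swap: a 1.5-fold higher number from compound 2 to compound 3 (0.18 log units; within the scatter). It is a change at the same kind of place, although the two compounds involved also differ from compound 1 elsewhere. Even so, it is the only guide, and it stays within the scatter. No measured compound carries methylcarbamoyl, so the data give no direct reading of this group and no reason to expect a direction.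

The expected step is a 1.1-fold higher number from compound 1 to compound 4 (0.04 log units; within the scatter), which means no shift beyond the scatter is anticipated in this assay. For compound 4 the estimate is 1000 nM, with an expected range from 450 nM to 2200 nM.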

Compound 4, half-maximal inhibitory concentration: 1100 nM
Compound 4: middle estimate off by 1.1-fold (0.04 log units), on the low side; low and high end bracket the measured number.
By their numbers in this assay, from the lowest: compounds 2, 3, 1 and 4 (each within the scatter of the next, the first and the last beyond it).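

In this assay, replacing (methanesulfonamido)methyl with methylcarbamoyl gives a 1.2-fold higher number from compound 1 to compound 4 (0.08 log units; within the scatter) and so leaves the number within the scatter. For the compounds shown here, this is the first direct reading of this swap, on a saturated chain carbon bound to a saturated ring carbon, and it shows that the sulfonyl-bearing chain can give way to an amide-bearing one with fewer heavy atoms and no shift that the assay can resolve; together with a 1.5-fold higher number from compound 2 to compound 3 (0.18 log units; within the scatter), it makes two steps at this kind of place, and neither goes beyond the scatter. Nothing at hand explains why the number holds steady across this change.

The compounds shown do not say whether any group at this place can move the number beyond the scatter, since all the side chains here are neutral, and a primary amine, a carboxylic acid or a longer chain ending in an amide could each give a different reading. From the compounds shown here alone, it also stays open whether the same swap would give so small a step on compound 2, which carries two chlorines on its phenyl ring in place of the two fluorines of compound 1.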